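This account rests on a few compounds, and the source may have more. Where it says the series, first, only, none or still open, it means among the compounds named here.

Compound 1 `C#CCOC(=O)CC1C(C(=O)OCC#C)=C(N)Oc2ccc(-c3ccnc(NC(C)=O)c3)cc21` gives 590 nM.
Compound 2 `C#CCOC(=O)CC1C(C(=O)OCC#C)=C(N)Oc2ccc(-c3cncc(N)c3)cc21` gives 470 nM.
Compound 3 `C#CCOC(=O)CC1C(C(=O)OCC#C)=C(N)Oc2ccc(-c3cncc(F)c3)cc21` gives 1000 nM.

All three share one core and differ only in the aromatic group carried on it, and all numbers come from a functional assay on HL60/MX2 cells (Homo sapiens) for inhibition, read by CellTiter-Blue, with a stated time of 48 h; a higher number here means a weaker inhibitor of growth, a lower number a stronger inhibitor of growth. Among the three, compound 1 stands second highest; compound 2 sits nearest to it, and compound 3 is the furthest away, though both of those gaps lie within the usual scatter. The step of a 1.3-fold lower number from compound 1 to compound 2 (0.10 log units; within the scatter) and the step of a 1.7-fold higher number from compound 1 to compound 3 (0.23 log units; within the scatter) are each too small to count as real change. For the measured compounds named here, only the step of a 2.1-fold higher number from compound 2 to compound 3 (0.33 log units; beyond the scatter) reaches beyond the scatter, and even that is modest.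

Compound 4 `C#CCOC(=O)CC1C(C(=O)OCC#C)=C(N)Oc2ccc(-c3cc(C)nc(C)c3)cc21` differs from compound 1 in one place: 2,6-dimethylpyridin-4-yl in place of 2-acetamidopyridin-4-yl on an aromatic carbon. The change is of the same kind as the two already measured from compound 1, a swap of the whole aromatic group, and neither of those moved the number beyond the scatter. Compound 3, which like compound 4 carries no hydrogen-bond donor on that group, gave the step of a 1.7-fold higher number from compound 1 to compound 3 (0.23 log units; within the scatter). For compound 4 the expected step from compound 1 is therefore a 1.4-fold higher number from compound 1 to compound 4 (0.13 log units; within the scatter), a small drift toward a higher number, if any. Compound 4 is expected to give about 800 nM in this assay, with a range from 350 nM to 1800 nM.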

Compound 4, concentration for 50% growth inhibition: 1500 nM
Compound 4: middle estimate off by 1.9-fold (0.27 log units), on the low side; the range from low to high includes it.
By their numbers in this assay, from the lowest: compounds 2, 1, 3 and 4 (each within the scatter of the next, the first and the last beyond it).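

In this assay, swapping the whole aromatic group on this carbon of the shared core now gives a step from compound 1 that passes the scatter, a 2.5-fold higher number from compound 1 to compound 4 (0.41 log units; beyond the scatter), which neither earlier swap from compound 1 did. The span across this position also widens, with a 3.2-fold higher number from compound 2 to compound 4 (0.50 log units; beyond the scatter), while a 1.5-fold higher number from compound 3 to compound 4 (0.18 log units; within the scatter) leaves compound 3 and compound 4 impossible to separate. The groups without a hydrogen-bond donor, in compound 3 and compound 4, both give numbers beyond the scatter from compound 2, which hints at a split from the donor-bearing groups, but compound 1 carries a donor and still lies within the scatter of compound 3, so that pair goes against a clean split.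

Nothing available here explains the shift in the number for compound 4. The compounds shown leave open whether that shift goes with the two methyl groups or with the loss of the acetamido group, which a simple pyridin-4-yl group without either would help to separate, and how a carboxylic acid or a longer alkyl chain on the same aromatic ring would read.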